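A few compounds are considered here, and "the series" means these few. Any claim that something is new, unique, unknown or untested is made for them only; others in the source may bear on it.

Compound 3 `O=C(CCc1ccc(-c2cccc(Cl)c2)cc1)N1CCCC1` is the weakest of the three compounds measured in an assay on HEK293 cells for inhibition of N-acylethanolamine-hydrolyzing acid amidase (Rattus norvegicus), read by LC-MS, with a stated time of 30 min (on this read-out lower numbers stand for stronger inhibition and higher numbers for weaker inhibition), where compound 3 gives 25400 nM. The two others differ from it only in the ring that carries a halogen: compound 1 `O=C(CCc1ccc(-c2cccc(F)c2)cc1)N1CCCC1` gives 1800 nM, and compound 2 `O=C(CCc1ccc(-c2ccc(F)cc2)cc1)N1CCCC1` gives 3400 nM. The step of a 1.9-fold higher number from compound 1 to compound 2 (0.28 log units; within the scatter) shows that shifting the fluorine from one position to another left the read-out essentially unchanged, whereas a 14-fold higher number from compound 1 to compound 3 (1.15 log units; beyond the scatter) and a 7.5-fold higher number from compound 2 to compound 3 (0.87 log units; beyond the scatter) show the chlorine-bearing compound 3 lagging clearly behind both fluorine-bearing compounds.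

Compound 4 `O=C(CCc1ccc(-c2ccccn2)cc1)N1CCCC1` differs from compound 3 in one place: pyridin-2-yl in place of 3-chlorophenyl on an aromatic carbon. Among the compounds with values here, the change removes the chlorine that accompanies the weak result of compound 3 and brings in a ring nitrogen that no measured compound carries. Within the data shown here, the steps that bear on it are a 14-fold higher number from compound 1 to compound 3 (1.15 log units; beyond the scatter) and a 7.5-fold higher number from compound 2 to compound 3 (0.87 log units; beyond the scatter), both large and both pointing to chlorine as the feature associated with the weaker number. The effect of the pyridine nitrogen itself is shown by no measured compound, so the estimate must be wide. Compound 4 is therefore expected to give 5000 nM, with a range from 1000 nM to 30000 nM. The expected step of a 5.1-fold lower number from compound 3 to compound 4 (0.71 log units; beyond the scatter) is toward stronger inhibition.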

Compound 4, half-maximal inhibitory concentration: > 100000 nM
Compound 4: no number, only a limit; the forecaster's own chance of this, stated with the estimate: 10%; middle value at least 20-fold (1.30 log units) away from the limit.
By their numbers in this assay, from the lowest: compounds 1 and 2 (each within the scatter of the next); then compound 3. At a limit, above all of these: compound 4.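

In this assay compound 4 gives > 100000 nM, which is a limit of the assay and not a number. The steps of an at least 3.9-fold higher number from compound 3 to compound 4 (0.59 log units; beyond the scatter), an at least 29-fold higher number from compound 2 to compound 4 (1.46 log units; beyond the scatter) and an at least 55-fold higher number from compound 1 to compound 4 (1.74 log units; beyond the scatter) all point the same way, so pyridin-2-yl, on this aromatic carbon para to a group of 9 heavy atoms, gives weaker inhibition than each of the three halogen-bearing phenyl rings. The earlier compounds shown here varied only the halogen and its place on a carbon-only ring, whereas compound 4 shows that losing the chlorine does not by itself restore inhibition and that the change of ring can weaken it further than the chlorine did.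

Compound 4 both lacks a halogen and carries a ring nitrogen, so the compounds shown cannot separate the two changes; a plain phenyl ring with no halogen would be the direct test. Going by these compounds, whether the place of the nitrogen matters also remains open, and pyridin-3-yl or pyridin-4-yl at the same carbon would address that.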